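Chloro to methyl on the aryl ether: outlook for compound 3

The compounds below may be only part of what the source reports. "The series", "measured", "known", "first", "only" and "open" are said of these compounds alone.

Measured so far:
compound 1 `CN1CCN(c2nc(N)nc(COc3ccccc3Cl)n2)CC1` — 129 nM
compound 2 `Cc1ccc(C(C)C)c(OCc2nc(N)nc(N3CCN(C)CC3)n2)c1` — 11 nM

In an assay on HEK293 cells for displacement of a labelled ligand from 5-hydroxytryptamine receptor 6 (Homo sapiens), read by radioligand binding, with a stated time of 1 h (on this read-out lower numbers stand for stronger inhibition and higher numbers for weaker inhibition), compound 1 gives 129 nM, the higher of the two numbers measured. Compound 2 gives 11 nM in this assay, and the gap between compound 2 and compound 1 lies beyond the usual scatter; the two compounds differ in several places at once, so the pair shows only that the series spans a wide range.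

Compound 3 `Cc1ccccc1OCc1nc(N)nc(N2CCN(C)CC2)n1` is the variant of compound 1 in which (methyl in place of chloro on an aromatic carbon). Among the compounds with values here, no pair of measured compounds isolates this single change, so there is no measured step to lean on. The expectation is therefore a step of small size, at most modestly toward a lower number, and the expected step from compound 1 to compound 3 is a 1.3-fold lower number from compound 1 to compound 3 (0.11 log units; within the scatter), within the scatter. Compound 3 is estimated at 100 nM, with a range of 35 nM to 300 nM.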

Compound 3, inhibition constant: 87 nM
Compound 3: middle estimate off by 1.1-fold (0.06 log units), on the high side; the measured number falls inside the stated range.
By their numbers in this assay, from the lowest: compound 2; then compounds 3 and 1 (each within the scatter of the next).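

In this assay, within the data shown here, methyl in place of chloro on an aromatic carbon, ortho to a large group, gives a 1.5-fold lower number from compound 1 to compound 3 (0.17 log units; within the scatter) as the first step that isolates a single place. At this place, the 2-chlorophenyl and 2-methylphenyl forms cannot be told apart on this read-out, so the exchange of these two groups leaves the affinity unresolved from the scatter. No measurement here speaks to the reason for this outcome.

Still open, going by these compounds, is whether a methoxy group, an amine or a longer chain such as ethyl at this same place would keep the number in this range or move it beyond the scatter. Also open, on these data alone, is whether the exchange of chloro and methyl would read the same way on the more substituted aryl ether of compound 2.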